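Hydroxy to nitro on the compound 2 scaffold

The source may report more compounds than this note shows. Statements on the series, on what has been measured and on what is new or still open speak of the compounds shown alone.

Measured in a functional assay on A549 cells (Homo sapiens) for cytotoxicity, read by MTT assay, with a stated time of 48 h; a higher number here means a weaker inhibitor, a lower number a stronger inhibitor:
compound 1 `COc1ccc(C2=NOC(COc3ccc(-c4nnnn4-c4cc(OC)c(OC)c(OC)c4)cc3N)C2)cc1OC` gives 2520 nM
compound 2 `COc1ccc(C2=NOC(COc3ccc(-c4nnnn4-c4cc(OC)c(OC)c(OC)c4)cc3N)C2)cc1O` gives 2130 nM

In this assay compound 2 stands at 2130 nM and compound 1 at 2520 nM, so the two cannot be told apart, and neither holds a clear place over the other. The compound now in question is compound 3 `COc1ccc(C2=NOC(COc3ccc(-c4nnnn4-c4cc(OC)c(OC)c(OC)c4)cc3N)C2)cc1[N+](=O)[O-]`, which keeps the shared core and differs from compound 2 in one group: nitro in place of hydroxy on an aromatic carbon. This puts nitro in place of hydroxy on an aromatic carbon, ortho to a methoxy group, turning 3-hydroxy-4-methoxyphenyl into 4-methoxy-3-nitrophenyl.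

Among the compounds with values here, the one measured step that bears on this change is a 1.2-fold lower number from compound 1 to compound 2 (0.07 log units; within the scatter), where hydrogen replaces methyl on an oxygen of that same group. It shows that this group tolerated one exchange without a change beyond the scatter. Within the data shown here, no measured compound carries a nitro group, however, so the evidence is thin and the range must stay wide. No step beyond the scatter is expected, and the estimated step is a 1.2-fold higher number from compound 2 to compound 3 (0.07 log units; within the scatter). Compound 3 is expected at 2500 nM, within a range of 1000 nM to 6000 nM.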

Compound 3, half-maximal inhibitory concentration: 2220 nM
Compound 3: the middle estimate sits 1.1-fold (0.05 log units) above what was measured, within the range that was stated.
By their numbers in this assay, from the lowest: compounds 2, 3 and 1 (each within the scatter of the next).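

In this assay, the position ortho to a methoxy group accepts a group of a different kind with no step beyond the scatter: a 1.0-fold higher number from compound 2 to compound 3 (0.02 log units; within the scatter), and a 1.1-fold lower number from compound 1 to compound 3 (0.06 log units; within the scatter). The earlier pair had shown only an exchange of hydrogen for methyl on an oxygen, with the ring still joined to oxygen in both compounds, whereas nitro joins the ring through nitrogen and the values stay within the scatter. Compound 1, compound 2 and compound 3 therefore cannot be told apart, so methoxy, hydroxy and nitro give no basis for ranking at this position on the shared core, and no evidence is available to account for this.

The compounds shown leave open whether a carboxylic acid, a chlorine atom or a longer chain such as butoxy at this position would produce a step beyond the scatter. They also leave open whether methoxy, hydroxy and nitro would remain indistinguishable in any assay other than this assay.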